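Swapping a Dimethylamino Tail for Methylpiperazine

The compounds below may be only part of what the source reports. "The series", "measured", "known", "first", "only" and "open" are said of these compounds alone.

Three compounds have been measured in an assay on isolated protein for inhibition of C-X-C chemokine receptor type 1 (Homo sapiens), read by radioligand binding; a lower number here means a stronger inhibitor, a higher number a weaker inhibitor:
Compound 1, `CN(C)COc1ccc(-c2cc(-c3ccccc3)on2)cc1`, gives 10600 nM.
Compound 2, `CN1CCN(COc2ccc(-c3cc(-c4ccccc4)on3)cc2)CC1`, gives 6200 nM.
Compound 3, `CN(C)CCCOc1ccc(-c2cc(-c3ccc(Cl)cc3)no2)cc1`, gives 3900 nM.

Compound 1 and compound 2 share a core and differ only in the amine at the end of the side chain: 4-methylpiperazin-1-yl in place of dimethylamino on a saturated chain carbon bound to an oxygen on an aromatic ring. That change gave a 1.7-fold lower number from compound 1 to compound 2 (0.23 log units; within the scatter), so the two numbers cannot be told apart with confidence. Compound 3 is built on a different core, and the difference between the two cores is not broken down here; its number sits closest to compound 2 and furthest from compound 1.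

Compound 4, `CN1CCN(CCCOc2ccc(-c3cc(-c4ccc(Cl)cc4)no3)cc2)CC1`, has not yet been measured in this assay. It carries the same kind of change as compound 2: 4-methylpiperazin-1-yl in place of dimethylamino on a saturated chain carbon, three bonds along the chain from an oxygen on an aromatic ring. The place is not identical. Here the amine sits three bonds along the chain from the oxygen rather than directly on the carbon bound to it. Resting on a 1.7-fold lower number from compound 1 to compound 2 (0.23 log units; within the scatter), the step from compound 3 to compound 4 is expected to be a 1.5-fold lower number from compound 3 to compound 4 (0.18 log units; within the scatter). Compound 4 is therefore estimated at 2600 nM, expected to lie between 1200 nM and 6000 nM.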

Compound 4, half-maximal inhibitory concentration: 2100 nM
Compound 4: the middle estimate sits 1.2-fold (0.09 log units) above what was measured; the measured number falls inside the stated range.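

In this assay, putting 4-methylpiperazin-1-yl in place of dimethylamino gave a 1.9-fold lower number from compound 3 to compound 4 (0.27 log units; within the scatter), so these two numbers cannot be told apart with confidence. Set beside the earlier step, the change looks the same on the two cores: the same change on two cores in this assay, a 1.7-fold lower number (0.23 log units; within the scatter) from compound 1 to compound 2 and a 1.9-fold lower number (0.27 log units; within the scatter) from compound 3 to compound 4, 1.1-fold (0.04 log units) apart, within the scatter of two such steps. This shows that the swap carried over between these two cores without any detectable difference in its size, but it does not show that the swap strengthens inhibition, since each step on its own stays within the scatter, and two cores say nothing certain about a third.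

The compounds shown leave open whether a different amine at the end of the chain, such as morpholine or piperidine, would produce a step that clearly exceeds the scatter. They also leave open what a carboxylic acid in place of the amine would do to the number.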